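A few compounds are considered here, and "the series" means these few. Any claim that something is new, unique, unknown or untested is made for them only; others in the source may bear on it.

Three compounds with the same core were tested in an ADME assay on 184B5 cells (Homo sapiens) for cytotoxicity, read by sulforhodamine B assay, with a stated time of 48 h; on this read-out higher numbers stand for weaker inhibition of growth and lower numbers for stronger inhibition of growth. Compound 1 `CN(C)CN1C(=O)C(=O)c2c(Br)cccc21` gives 77900 nM, and compound 2 `O=C1C(=O)N(CN2CCCCC2)c2cccc(Cl)c21` gives 93700 nM. Compound 3 `CCN(CC)CN1C(=O)C(=O)c2c(Cl)cccc21` gives 22500 nM, the lowest of the three numbers; the step of a 4.2-fold lower number from compound 2 to compound 3 (0.62 log units; beyond the scatter) shows how changing the amine at this position moves the read-out. Compound 4 `CN(C)CN1C(=O)C(=O)c2c(Cl)cccc21` differs from compound 3 by dimethylamino in place of diethylamino on a saturated chain carbon bound to an amide-type nitrogen in a ring. Among the measured compounds shown here, no measured pair covers exactly this change, but compound 1 also carries a dimethylamino group and gives 77900 nM, which is weaker than compound 3. A modest rise in this assay is therefore expected, about a 2.7-fold higher number from compound 3 to compound 4 (0.43 log units; beyond the scatter). Compound 4 is estimated at 60000 nM, with a likely range from 25000 nM to 140000 nM.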

Compound 4, concentration for 50% growth inhibition: 130000 nM
Estimate against measurement, compound 4: 2.2-fold (0.34 log units) below; low and high end bracket the measured number.
By their numbers in this assay, from the lowest: compound 3; then compounds 1, 2 and 4 (each within the scatter of the next).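

Replacing diethylamino with dimethylamino moves the number well beyond the scatter (a 5.8-fold higher number from compound 3 to compound 4 (0.76 log units; beyond the scatter)), so compound 3 stands apart within this amine series. Piperidin-1-yl and dimethylamino cannot be told apart here (a 1.4-fold higher number from compound 2 to compound 4 (0.14 log units; within the scatter)). With dimethylamino in place, neither can bromo and chloro on the aromatic carbon (a 1.7-fold higher number from compound 1 to compound 4 (0.22 log units; within the scatter)). From the compounds shown here alone, whether a morpholin-4-yl group or the longer dipropylamino group would track diethylamino or dimethylamino remains open. Nothing measured here explains why diethylamino stands apart.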